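Working notes: amine substituent and cytotoxicity in a small series

The compounds below may be only part of what the source reports. "The series", "measured", "known", "first", "only" and "open" are said of these compounds alone.

Measured so far:
compound 1, `CNC1=Nc2ccc(Cl)cc2C(C)(C)C1`: 92.3%
compound 2, `CC1(C)CC(NCc2ccccc2)=Nc2ccc(Cl)cc21`: 68.1%

In a functional assay on MDA-MB-231 cells (Homo sapiens) for cytotoxicity, read by MTT assay, with a stated time of 72 h, tested at 5 uM, in the absence of a further agent (on this read-out higher numbers stand for a weaker effect at the one concentration tested and lower numbers for a stronger effect), compound 1 gives the highest of the two numbers shown, that is the weaker effect at the single concentration; compound 2 gives 68.1%, a step of a number 24.2 percentage points lower from compound 1 to compound 2 (beyond the scatter). Compound 3, `CC1(C)CC(NCCCO)=Nc2ccc(Cl)cc21`, differs from compound 1 by 2-hydroxyethyl in place of hydrogen on a saturated chain carbon bound to an amine nitrogen. Going by the values given here, the only measured step at this position is the one to compound 2, and it bears on the expectation only in direction; no measured compound carries an oxygen-bearing chain here. A smaller group at the same place is expected to give a smaller step, a number 8.3 percentage points lower from compound 1 to compound 3 (within the scatter), possibly within the scatter. Compound 3 is estimated at 84%, in the range 66% to 100%.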

Compound 3, a percentage reported as activity, at one concentration (the size of the read-out at that concentration, not a potency): 84.2%
Beside the measured number, compound 3's estimate is 0.2 percentage points below it, within the range that was stated.
By their numbers in this assay, from the lowest: compound 2; then compounds 3 and 1 (each within the scatter of the next).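

In this assay the change from methylamino to (3-hydroxypropyl)amino gives a number 8.1 percentage points lower from compound 1 to compound 3 (within the scatter) and so this chain on the amine nitrogen does not separate the two compounds. At the same place, 2-hydroxyethyl in place of phenyl gives a number 16.1 percentage points higher from compound 2 to compound 3 (beyond the scatter) and so, among these three compounds, only compound 2 stands apart. No data at hand account for this difference.

Open, as far as these compounds go, is whether a cyclohexyl ring in place of the phenyl would read like compound 2 or like compound 3. Also open, from the compounds shown here alone, is how an amine or a carboxylic acid in place of the hydroxy group on the chain would read.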